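Quinoline sulfonyl amines: swapping the basic piperazine for a carboxamide

This account rests on a few compounds, and the source may have more. Where it says the series, first, only, none or still open, it means among the compounds named here.

Measured so far in an assay on isolated protein for displacement of a labelled ligand from metabotropic glutamate receptor 5 (Homo sapiens), with a stated time of 60 min, tested at 1 uM; a lower number here means less inhibition, a higher number more inhibition at the concentration tested (going by the name of the read-out):
- compound 1, `CCN1CCN(c2c(S(=O)(=O)c3ccccc3)cnc3ccccc23)CC1`: 1.7%
- compound 2, `CC1CCN(c2c(S(=O)(=O)c3ccccc3)cnc3c(F)cccc23)CC1`: 13%
- compound 3, `Cc1ccc2ncc(S(=O)(=O)c3cccc(C#N)c3)c(N3CCC(C)CC3)c2c1`: 52%

Compound 1 has the lowest of the three numbers in this assay. The nearest, compound 2, sits higher by more than the scatter, and compound 3 is higher still, well beyond it. Going by the values given here, no pair among the measured compounds differs in one place only, so no single step has been resolved.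

Compound 4, `NC(=O)C1CCN(c2c(S(=O)(=O)c3ccccc3)cnc3ccccc23)CC1`, differs from compound 1 in one place: 4-carbamoylpiperidin-1-yl in place of 4-ethylpiperazin-1-yl on an aromatic carbon. Among the compounds with values here, no measured step informs this change. Compound 4 is expected to show a small change, a number 6.3 percentage points higher from compound 1 to compound 4 (within the scatter), not clearly beyond the scatter. The estimate for compound 4 in this assay is 8%, with a range from 0% to 30%.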

Compound 4, a percentage reported as inhibition, at one concentration (the size of the read-out at that concentration, not a potency): 24.8%
Beside the measured number, compound 4's estimate is 16.8 percentage points below it, within the range that was stated.
By their numbers in this assay, from the lowest: compound 1; then compound 2; then compound 4; then compound 3.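

this assay gives the first resolved step in the series: 4-carbamoylpiperidin-1-yl in place of 4-ethylpiperazin-1-yl on the aromatic carbon opposite the ring nitrogen yields a number 23.1 percentage points higher from compound 1 to compound 4 (beyond the scatter). This position therefore responds to the group it carries, and a carboxamide-bearing piperidine is accepted on the core of compound 1. No evidence at hand bears on the cause of this step.

On these data alone, it remains open whether the step follows the carboxamide or the change of ring. A 4-ethylpiperidin-1-yl group on the same core would separate the two, and a carboxylic acid in place of the carboxamide would test that group further.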